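The source may hold more compounds than are shown below. What is called first, only, known or untested is meant among the compounds shown, and "the series" means these compounds.

Measured compounds:
- Compound 1, `Cc1nc(S(C)(=O)=O)ccc1Oc1ncnc(OC2CCN(C(=O)SC(C)(C)C)CC2)c1F`: 30.7 nM
- Compound 2, `Cc1nc(S(C)(=O)=O)ccc1Oc1ncnc(OC2CCN(C(=O)SC3CC3)CC2)c1F`: 126 nM
- Compound 3, `Cc1nc(S(C)(=O)=O)ccc1Oc1ncnc(OC2CCN(C(=S)OC3(C)CC3)CC2)c1F`: 48.8 nM

In a functional assay on isolated protein for inhibition of Glucose-dependent insulinotropic receptor (Rattus norvegicus), read by HTRF and cAMP accumulation (on this read-out lower numbers stand for an effect already at smaller amounts and higher numbers for an effect only at larger amounts of compound), compound 1 gives the lowest of the three numbers. Compound 3 lies nearest to it, as a 1.6-fold higher number from compound 1 to compound 3 (0.20 log units; within the scatter) shows, a gap within the scatter. Compound 2 lies furthest away, with a 4.1-fold higher number from compound 1 to compound 2 (0.61 log units; beyond the scatter), a modest step beyond the scatter.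

Compound 4, `Cc1nc(S(C)(=O)=O)ccc1Oc1ncnc(OC2CCN(C(=O)c3noc(C(C)(C)F)n3)CC2)c1F`, has not yet been measured. It differs from compound 1 in one place: a group of 9 heavy atoms (5 carbon, 2 nitrogen, 1 oxygen, 1 fluorine; one five-membered aromatic ring with 3 hetero atoms) in place of a group of 5 heavy atoms (4 carbon, 1 sulfur; no ring), on a carbonyl carbon. For the measured compounds named here, two measured steps touch the same carbonyl carbon. The step of a 4.1-fold higher number from compound 1 to compound 2 (0.61 log units; beyond the scatter) shows that a smaller group on the sulfur gives a higher number, while a 1.6-fold higher number from compound 1 to compound 3 (0.20 log units; within the scatter) shows that rearranging the atoms around the carbonyl hardly matters. Neither step removes the sulfur or introduces an aromatic ring, so the change to compound 4 reaches beyond what the measured steps cover. An expected outcome for compound 4 is therefore a number close to that of compound 1 or somewhat higher, with wide uncertainty, as the step of a 1.5-fold higher number from compound 1 to compound 4 (0.17 log units; within the scatter) expresses. Compound 4 is estimated at 45 nM, with a range from 10 nM to 200 nM.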

Compound 4, half-maximal effective concentration: 103 nM
Estimate against measurement, compound 4: 2.3-fold (0.36 log units) below, within the range that was stated.
By their numbers in this assay, from the lowest: compounds 1 and 3 (each within the scatter of the next); then compounds 4 and 2 (each within the scatter of the next).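

In this assay, the carbonyl carbon can carry a five-membered aromatic ring with 3 hetero atoms in place of the (tert-butyl)sulfanyl group and the compound still gives a measurable effect, though with a 3.4-fold higher number from compound 1 to compound 4 (0.53 log units; beyond the scatter). The ring-bearing group also gives a 2.1-fold higher number from compound 3 to compound 4 (0.32 log units; beyond the scatter), while its gap to the cyclopropyl group on sulfur stays within the scatter, at a 1.2-fold lower number from compound 2 to compound 4 (0.09 log units; within the scatter). No measured evidence on what lies behind these steps is available.

The compounds shown do not separate the loss of the sulfur from the entry of the ring or of its fluorine-bearing side chain. Going by these compounds, it remains open how a methyl group on that ring in place of this chain, or a dimethylamino group on the carbonyl carbon, would compare.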